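Acyl chain shortening and cytotoxicity in the series

A few compounds are considered here, and "the series" means these few. Any claim that something is new, unique, unknown or untested is made for them only; others in the source may bear on it.

Compound 1 `CCCCCCCC/C=C\CCCCCCCC(=O)Nc1nnc(S[C@@H]2O[C@H](COC(C)=O)[C@H](OC(C)=O)[C@H](OC(C)=O)[C@H]2OC(C)=O)s1` stands highest of the three numbers in a functional assay on HeLa cells (Homo sapiens) for cytotoxicity, read by MTT assay, with a stated time of 24 h (a lower number here means a stronger inhibitor, a higher number a weaker inhibitor), giving 54400 nM. Compound 2 `CCCCCCCCCCCCCCCCCC(=O)Nc1nnc(S[C@@H]2O[C@H](CO)[C@H](O)[C@H](O)[C@H]2O)s1` gives 11200 nM and compound 3 `CCCCCCCCCCCCCC(=O)Nc1nnc(S[C@@H]2O[C@H](CO)[C@H](O)[C@H](O)[C@H]2O)s1` gives 31000 nM; compound 3 lies within the scatter of compound 1, while compound 2 lies beyond it. Compound 4 `CCCCCCCCCCCC(=O)Nc1nnc(S[C@@H]2O[C@H](COC(C)=O)[C@H](OC(C)=O)[C@H](OC(C)=O)[C@H]2OC(C)=O)s1` differs from compound 1 by butyl in place of dec-1-en-1-yl on a saturated chain carbon, seven bonds along the chain from a carbonyl carbon. Going by the values given here, the one measured step that bears on this is a 2.8-fold higher number from compound 2 to compound 3 (0.44 log units; beyond the scatter), in which the shorter chain went with the higher number. The change to compound 4 removes more of the chain than that step did, so an upward step of roughly that size or somewhat larger is expected, a 2.4-fold higher number from compound 1 to compound 4 (0.38 log units; beyond the scatter). Compound 4 is therefore estimated at 130000 nM, within a range of 50000 nM to 300000 nM.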

Compound 4, half-maximal inhibitory concentration: 51900 nM
Compound 4: middle estimate off by 2.5-fold (0.40 log units), on the high side; the range from low to high includes it.
By their numbers in this assay, from the lowest: compound 2; then compounds 3, 4 and 1 (each within the scatter of the next).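

In this assay, butyl in place of dec-1-en-1-yl, on a saturated chain carbon seven bonds along the chain from a carbonyl carbon, gives a 1.0-fold lower number from compound 1 to compound 4 (0.02 log units; within the scatter) and so leaves the two compounds indistinguishable. The link between a shorter chain and a higher number seen in a 2.8-fold higher number from compound 2 to compound 3 (0.44 log units; beyond the scatter) therefore does not carry over to this acetate-bearing pair. No evidence at hand bears on this result.

Open, as far as these compounds go, is whether a longer chain or a terminal amine at this position would separate from compound 1 in this assay and whether the free-hydroxyl forms of compound 1 and compound 4 would behave alike.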